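This account rests on a few compounds, and the source may have more. Where it says the series, first, only, none or still open, it means among the compounds named here.

Working notes on the series, read in a functional assay on the whole organism for agonist activity, with Mus musculus as the target; a higher number here means that more compound is needed for the effect, a lower number that less compound is needed. Within the data shown here, compound 1 (`CC(=O)N(C)C(C)C#CCn1ccnc1`) gives 2 mg/kg, the only exact number so far. Compound 2 (`CC(=O)N(C)C(C)C#CCn1cncc1C`) is reported as > 100 mg/kg, which is a limit of the assay and not a number. Compound 3 (`CC(=O)N(C)C(C)C#CCn1ccnc1C`) differs from compound 1 by methyl in place of hydrogen on an aromatic carbon, between two ring nitrogen atoms, next to the ring atom that bears a large group. Among the measured compounds shown here, one measured step bears on this change: an at least 50-fold higher number from compound 1 to compound 2 (1.69 log units; beyond the scatter), large and beyond the scatter, with the same exchange made at a different ring carbon. That single step is only a partial guide, yet it points to a higher number. The expected step is a 13-fold higher number from compound 1 to compound 3 (1.10 log units; beyond the scatter), large and upward. For compound 3 the estimated value is 25 mg/kg, with an expected range of 5 mg/kg to 100 mg/kg.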

Compound 3, dose for half-maximal effect: > 100 mg/kg
Compound 3: no number, only a limit; the forecaster's own chance of this, stated with the estimate: 45%; middle value at least 4.0-fold (0.60 log units) away from the limit.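

At this position, between two ring nitrogen atoms and next to the ring atom that bears a large group, methyl in place of hydrogen on an aromatic carbon also brings, in this assay, an at least 50-fold higher number from compound 1 to compound 3 (1.69 log units; beyond the scatter). Compound 3 gives > 100 mg/kg, which is a limit of the assay and not a number. The large upward step is therefore no longer confined to one ring carbon, yet compound 2 and compound 3 cannot be ordered against each other, and the size of each step is bounded on one side only: the limit of > 100 mg/kg in this assay, at which 2 of the 3 values shown sit.

Open, from the compounds shown here alone, is whether the step belongs to methyl itself or to any replacement of hydrogen on these ring carbons. A fluorine atom or an amine at the same position would separate those two readings.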